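The source may report more compounds than this note shows. Statements on the series, on what has been measured and on what is new or still open speak of the compounds shown alone.

Working notes on the series. Three compounds carry the shared core of compound 1 `O=C1CCCCC1C1CC(=O)N(c2ccccc2)C1=O` with an unsubstituted phenyl on the imide nitrogen. In an assay on Sf21 cells for inhibition of cytochrome c oxidase subunit 2 (Homo sapiens), read by spectrophotometry, with a stated time of 5 min (on this read-out lower numbers stand for stronger inhibition and higher numbers for weaker inhibition), compound 1 gives 45100 nM. Compound 2 `CC(=O)CC1CC(=O)N(c2ccccc2)C1=O` carries an acetonyl chain in place of the cyclic ketone and in this assay compound 2 gives 63900 nM. Compound 3 `O=C1CCCCCC1C1CC(=O)N(c2ccccc2)C1=O` carries a seven-membered ketone ring and in this assay compound 3 gives 39500 nM. On these numbers compound 1 is second highest of three, yet its gap to compound 3 and its gap to compound 2 both lie within the scatter, so the three read as one level.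

Compound 4 `O=C1CCCCC1C1CC(=O)N(c2ccc(Br)cc2)C1=O` differs from compound 1 only on the aromatic ring: bromo in place of hydrogen on an aromatic carbon. Among the measured compounds shown here, no measured pair in the set reports the effect of a halogen on this ring, and the ketone-side variation gives no guidance for it. The step from compound 1 to compound 4 is expected to be small, a 1.3-fold lower number from compound 1 to compound 4 (0.11 log units; within the scatter), with no direction beyond the scatter claimed. Compound 4 is estimated at 35000 nM in this assay, within a range of 12000 nM to 100000 nM.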

Compound 4, half-maximal inhibitory concentration: 113000 nM
Compound 4: middle estimate off by 3.2-fold (0.51 log units), on the low side; measured number outside the range, above it.
By their numbers in this assay, from the lowest: compounds 3, 1, 2 and 4 (each within the scatter of the next, the first and the last beyond it).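

In this assay, the aromatic ring shows a response that the ketone-side variation in compound 1, compound 2 and compound 3 did not, as those three read as one level while phenyl to 4-bromophenyl gives a 2.5-fold higher number from compound 1 to compound 4 (0.40 log units; beyond the scatter) and this modest step lies beyond the scatter. Bromo on this aromatic carbon, para to a large group, therefore moves the read-out toward weaker inhibition, so this position is not indifferent to substitution, on the evidence of this single pair. Nothing available accounts for the step.

As far as these compounds go, whether a fluoro, a methoxy or an amine on the same aromatic carbon would move the number in the same direction remains open. Also open, from the compounds shown here alone, is whether the bromo step would carry over to the acetonyl chain of compound 2 or the seven-membered ketone ring of compound 3.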